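Capping the remaining phenol of compound 2 with a prenyl chain

The source may hold more compounds than are shown below. What is called first, only, known or untested is meant among the compounds shown, and "the series" means these compounds.

Compound 2 `COc1cc(C2Oc3cc(-c4oc5cc(OCC=C(C)C)cc(O)c5c(=O)c4O)ccc3OC2CO)ccc1O` sits second highest among the three numbers measured in a functional assay on liver (Rattus norvegicus, strain Sprague-Dawley) for inhibition, with a stated time of 1 h; a higher number here means a weaker inhibitor, a lower number a stronger inhibitor; compound 2 gives 23300 nM. Compound 1 `CCOC(=O)COc1cc(O)c2c(=O)c(O)c(-c3ccc4c(c3)OC(c3ccc(OCC(=O)OCC)c(OC)c3)C(CO)O4)oc2c1` gives 36400 nM, which lies within the scatter of compound 2. Going by the values given here, compound 3 `CCN(CC)C(=O)COc1cc(O)c2c(=O)c(O)c(-c3ccc4c(c3)OC(c3ccc(O)c(OC)c3)C(CO)O4)oc2c1` gives 700 nM, the lowest number in this assay; the step of a 33-fold lower number from compound 2 to compound 3 (1.52 log units; beyond the scatter) is the only single-point change measured, and it concerns the chain on the core, not the second aryl ring.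

Compound 4 `COc1cc(C2Oc3cc(-c4oc5cc(OCC=C(C)C)cc(O)c5c(=O)c4O)ccc3OC2CO)ccc1OCC=C(C)C` differs from compound 2 at the other end of the molecule: 3-methylbut-2-en-1-yl in place of hydrogen on an oxygen on an aromatic ring. Among the compounds with values here, no measured step bears directly on this change. Compound 1 carries a substituent on that same oxygen while also differing elsewhere, and its value against compound 2 shows no difference beyond the scatter. On that basis the step of a 1.1-fold higher number from compound 2 to compound 4 (0.03 log units; within the scatter) is expected to stay within the scatter. Compound 4 is therefore estimated at 25000 nM, with a range from 8000 nM to 70000 nM.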

Compound 4, half-maximal inhibitory concentration: 28100 nM
Beside the measured number, compound 4's estimate is 1.1-fold (0.05 log units) below it; measured number inside the range.
By their numbers in this assay, from the lowest: compound 3; then compounds 2, 4 and 1 (each within the scatter of the next).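

In this assay, going by these compounds alone, a 1.2-fold higher number from compound 2 to compound 4 (0.08 log units; within the scatter) gives the first reading of this oxygen changed alone, whereas compound 1 carries a substituent there together with a different chain on the core. With 3-methylbut-2-en-1-yl already on the other oxygen of the shared core, hydroxy to (3-methylbut-2-en-1-yl)oxy on this aromatic ring therefore leaves the number within the scatter, so the free hydroxy is not required to keep the value at this level. No available evidence accounts for this result.

As far as these compounds go, it remains open whether the same change would also stay within the scatter in compound 3, which gives 700 nM with the hydroxy kept. Also unresolved is whether a chain ending in an amine or a carboxylic acid on this oxygen would move the number beyond the scatter.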